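This account rests on a few compounds, and the source may have more. Where it says the series, first, only, none or still open, it means among the compounds named here.

Going by the values given here, in an ADME assay on the whole organism (strain Swiss Webster) for metabolic stability, with Mus musculus as the target, using cassette dosing, at a dose of 0.3 mg/kg by the oral route (a higher number here means that the compound lasts longer, a lower number that the compound disappears faster), compound 2 `CCC(C)C(=O)N1CCC(NC(=O)Nc2ccc(C(C)C)cc2)CC1` gives 2 h, the lower of the two numbers so far, and compound 1 `O=C(Nc1ccc(C(F)(F)F)cc1)NC1CCN(C(=O)C2CC2)CC1` gives 17 h. The gap between these two compounds lies beyond the scatter. Compound 3 `CCC(C)C(=O)N1CCC(NC(=O)Nc2ccc(C(F)(C(F)(F)F)C(F)(F)F)cc2)CC1` carries 1,2,2,2-tetrafluoro-1-(trifluoromethyl)ethyl in place of isopropyl on an aromatic carbon of compound 2 (1,2,2,2-tetrafluoro-1-(trifluoromethyl)ethyl in place of isopropyl on an aromatic carbon). Among the compounds with values here, no measured pair shows this change alone. Compound 1 carries trifluoromethyl and gives 17 h, but it also differs from compound 2 elsewhere, so it offers only a loose guide. A rise beyond the scatter is expected in this assay, with an estimated step of a 5.0-fold higher number from compound 2 to compound 3 (0.70 log units; beyond the scatter). For compound 3, the expected half-life is 10 h, within an estimated range of 4 h to 28 h.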

Compound 3, half-life: 4.5 h
Compound 3: the middle estimate sits 2.2-fold (0.35 log units) above what was measured, within the range that was stated.
By their numbers in this assay, from the lowest: compound 2; then compound 3; then compound 1.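

In this assay, putting 1,2,2,2-tetrafluoro-1-(trifluoromethyl)ethyl in place of isopropyl gives a 2.3-fold higher number from compound 2 to compound 3 (0.35 log units; beyond the scatter), so this position affects the half-life even when the rest of the molecule stays fixed. Compound 1 could not show this, as it differs from compound 2 in more than one place. No measurement here explains the rise.

As far as these compounds go, it remains open how a nitrile or a chlorine atom would behave at this position on the same core. The share of the other differences in the higher number of compound 1 also remains unresolved.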